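Replacing 4-iodophenyl in compound 3 with 3-nitrophenyl

The source may hold more compounds than are shown below. What is called first, only, known or untested is meant among the compounds shown, and "the series" means these compounds.

Measured in a functional assay on CCRF-CEM cells (Homo sapiens) for antiproliferative activity; a lower number here means a stronger inhibitor, a higher number a weaker inhibitor:
Compound 1 `COc1cc(C(=O)c2sc(-c3ccc(Br)cc3)cc2N)cc(OC)c1OC`: 86 nM
Compound 2 `COc1ccc(-c2cc(N)c(C(=O)c3cc(OC)c(OC)c(OC)c3)s2)cc1OC`: 20 nM
Compound 3 `COc1cc(C(=O)c2sc(-c3ccc(I)cc3)cc2N)cc(OC)c1OC`: 150 nM

Compound 3 cannot be told apart from compound 1, with a 1.7-fold higher number from compound 1 to compound 3 (0.24 log units; within the scatter), but stands clear of compound 2, with a 7.5-fold higher number from compound 2 to compound 3 (0.88 log units; beyond the scatter). Compound 4 `COc1cc(C(=O)c2sc(-c3cccc([N+](=O)[O-])c3)cc2N)cc(OC)c1OC` has 3-nitrophenyl in place of 4-iodophenyl on an aromatic carbon. For the measured compounds named here, no measured compound carries 3-nitrophenyl. The closest guide is compound 2, the only one without a halogen, with a 4.3-fold lower number from compound 1 to compound 2 (0.63 log units; beyond the scatter). One compound is thin support, so only a small step toward a lower number is expected in this assay. The estimated change is a 1.9-fold lower number from compound 3 to compound 4 (0.27 log units; within the scatter). For compound 4 the estimated value is 80 nM, with an expected range from 20 nM to 300 nM.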

Compound 4, half-maximal inhibitory concentration: 5.9 nM
Compound 4: the middle estimate sits 14-fold (1.13 log units) above what was measured, and the stated range ends above it.
By their numbers in this assay, from the lowest: compound 4; then compound 2; then compounds 1 and 3 (each within the scatter of the next).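

In this assay the position next to the ring sulfur turns out to allow far more than the halogen-bearing groups suggested: 3-nitrophenyl gives a 25-fold lower number from compound 3 to compound 4 (1.41 log units; beyond the scatter) and a 15-fold lower number from compound 1 to compound 4 (1.16 log units; beyond the scatter) when set against the two halogenated rings. It also passes 3,4-dimethoxyphenyl, the best earlier group, with a 3.4-fold lower number from compound 2 to compound 4 (0.53 log units; beyond the scatter) and so compound 4 is the strongest of the four.

The change swaps both the substituent on the phenyl ring and its place on that ring, so these compounds cannot separate the two, and 4-nitrophenyl or 3-aminophenyl would be needed to do so. Nothing available here explains the gain.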